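The source may report more compounds than this note shows. Statements on the series, on what has been measured and on what is new or still open speak of the compounds shown alone.

Compound 1, `O=S(=O)(Nc1nccs1)c1ccc2c(c1)OCC[C@@H]2c1ccc(C(F)(F)F)cc1N1CCNCC1`, carries a piperazin-1-yl group on its aromatic ring. In a physicochemical assay for lipophilicity (on this read-out lower numbers stand for lower lipophilicity and higher numbers for higher lipophilicity), compound 1 gives 1.4, the lowest of the two numbers recorded so far. Compound 2, `Cn1nccc1-c1cc(C(F)(F)F)ccc1[C@@H]1CCOc2cc(S(=O)(=O)Nc3nccs3)ccc21`, gives 2.2 in this assay, a value standing beyond the scatter above that of compound 1. Compound 3, `O=C1COCCN1c1cc(C(F)(F)F)ccc1[C@H]1CCOc2cc(S(=O)(=O)Nc3nccs3)ccc21`, has not yet been measured. It differs from compound 1 in a single place: 3-oxomorpholin-4-yl in place of piperazin-1-yl on an aromatic carbon. Among the measured compounds shown here, no step between measured compounds covers this change, so the size of the step has to be judged from the two values shown. Compound 3 is expected to move upward from compound 1 in this assay by a number 0.90 log units higher from compound 1 to compound 3 (beyond the scatter), a step expected to be larger than the scatter. For compound 3 the estimated value in this assay is 2.3, with a range from 1.7 to 2.9.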

Compound 3, distribution coefficient: 1.8
Beside the measured number, compound 3's estimate is 0.50 log units above it; low and high end bracket the measured number.
By their numbers in this assay, from the lowest: compound 1; then compound 3; then compound 2.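

In this assay, among the compounds shown here, the exchange of piperazin-1-yl for 3-oxomorpholin-4-yl on this aromatic carbon, ortho to a large group, gives a number 0.40 log units higher from compound 1 to compound 3 (beyond the scatter) as the first step that can be read at this position. The step is modest, and it comes with the loss of the hydrogen-bond donor and the arrival of a double bond outside aromatic rings, while both groups remain six-membered non-aromatic rings with the same count of acceptors. Nothing measured here accounts for the size of the step. The compounds shown leave open how morpholin-4-yl, the same ring without the carbonyl, would stand relative to these two groups in this assay at this position. Also open, from the compounds shown here alone, is whether 4-methylpiperazin-1-yl at this place would stay close to piperazin-1-yl on this read-out.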